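This account rests on a few compounds, and the source may have more. Where it says the series, first, only, none or still open, it means among the compounds named here.

Within the data shown here, compound 2, built as `O=S(=O)(c1cccc(F)c1)c1ccc2c(c1)CCC[C@H]2CN1CC(O)C1`, gives 0.1 nM in an assay on isolated protein for displacement of a labelled ligand from 5-hydroxytryptamine receptor 6 (Homo sapiens) (on this read-out lower numbers stand for stronger inhibition and higher numbers for weaker inhibition), and that is the lowest of the two numbers so far. Among the measured compounds shown here, the only other measured compound is compound 1, `CN(C)S(=O)(=O)NC[C@@H]1CCCc2cc(S(=O)(=O)c3cccc(F)c3)ccc21`, which in this assay gives 2 nM; the step of a 20-fold lower number from compound 1 to compound 2 (1.30 log units; beyond the scatter) is the one change recorded. Compound 3, `NC(=O)CNC[C@@H]1CCCc2cc(S(=O)(=O)c3cccc(F)c3)ccc21`, is not yet measured. It differs from compound 2 by (carbamoylmethyl)amino in place of 3-hydroxyazetidin-1-yl on a saturated chain carbon bound to a saturated ring carbon. The measured step bears on this change only in part: it shows that exchanging the group on this saturated chain carbon moves the number a long way, and it shows that the ring-bearing group of compound 2 sits at the favourable end, while the open-chain amino group of compound 1 sits at the unfavourable end. Compound 3 likewise carries an open-chain amino group here, so a move back toward the number of compound 1 is expected, though a smaller one, and the estimate for compound 3 in this assay is 1 nM, within 0.2 nM to 5 nM. This estimate means a step of a 10-fold higher number from compound 2 to compound 3 (1.00 log units; beyond the scatter), expected to be beyond the scatter.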

Compound 3, inhibition constant: 0.1 nM
Estimate against measurement, compound 3: 10-fold (1.00 log units) above; measured number outside the range, below it.
By their numbers in this assay, from the lowest: compounds 2 and 3 (each within the scatter of the next); then compound 1.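

In this assay the step of no change at the digits printed from compound 2 to compound 3 (within the scatter) shows that a ring on this saturated chain carbon is not needed for a number at this level, as the open-chain (carbamoylmethyl)amino group and the 3-hydroxyazetidin-1-yl group cannot be told apart here. The step of a 20-fold lower number from compound 1 to compound 3 (1.30 log units; beyond the scatter) shows that the weaker number of compound 1 does not follow from an open chain as such, since carbamoylmethyl in place of dimethylsulfamoyl on the same amine nitrogen gives a large move. No measurement at hand explains either result.

Still open is whether the carbamoylmethyl group's carbonyl and terminal amide matter, as the compounds shown include no plain methyl or carboxylic acid on this amine nitrogen. Also open, on these data alone, is whether a longer chain ending in the same amide would keep the number.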